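Diethylamino in place of amino: N-methyl anilide series

The source may hold more compounds than are shown below. What is called first, only, known or untested is meant among the compounds shown, and "the series" means these compounds.

Measured compounds:
Compound 1 `CN(C(=O)CNC(=O)CN)c1ccc(Cl)cc1C(=O)c1ccccc1Cl` — 0.58 mg/kg
Compound 2 `CC(=O)NCC(=O)Nc1ccc(Cl)cc1C(=O)c1ccccc1` — 37 mg/kg
Compound 3 `NCC(=O)NCC(=O)Nc1ccc([N+](=O)[O-])cc1C(=O)c1ccccc1` — 4.82 mg/kg

In a functional assay on the whole organism for antagonist activity, with Mus musculus as the target (a lower number here means that less compound is needed, a higher number that more compound is needed for the effect), compound 1 gives the lowest of the three numbers. The nearest is compound 3, whose value of 4.82 mg/kg lies beyond the scatter of that of compound 1; compound 2, with 37 mg/kg, is furthest, also beyond the scatter. Going by the values given here, no pair of these three differs in only one place, so no single step can be read off among the measured compounds.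

Compound 4 `CCN(CC)CC(=O)NCC(=O)N(C)c1ccc(Cl)cc1C(=O)c1ccccc1Cl` is not yet measured. It differs from compound 1 by diethylamino in place of amino on a saturated chain carbon bound to a carbonyl carbon on a saturated chain carbon bound to a carbonyl carbon. Among the compounds with values here, no measured pair shows this change, so its effect is open. Within the data shown here, compound 1 and compound 3 both carry the amino group and both stand low, while compound 2 carries no amino group and stands high; this is a comparison across several changes at once and gives no direct step.

In this assay a step from compound 1 to compound 4 of a 1.7-fold higher number from compound 1 to compound 4 (0.24 log units; within the scatter) is expected, most likely within the scatter or only just beyond it, toward a higher number. Compound 4 is therefore estimated at 1 mg/kg, with a range of 0.3 mg/kg to 4 mg/kg.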

Compound 4, dose for half-maximal effect: 2.2 mg/kg
The estimate for compound 4 lay 2.2-fold (0.34 log units) below the measured number; the measured number falls inside the stated range.
By their numbers in this assay, from the lowest: compound 1; then compound 4; then compound 3; then compound 2.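

In this assay, going by these compounds alone, diethylamino in place of amino on a saturated chain carbon bound to a carbonyl carbon gives a 3.8-fold higher number from compound 1 to compound 4 (0.58 log units; beyond the scatter), the first single-change step. The position therefore registers the change, beyond the scatter, yet the effect survives: without the hydrogen-bond donor counted for amino, compound 4 still gives 2.2 mg/kg, so a free amino group at this place is not required for activity in this whole-organism assay. No measured evidence bears on what produces the step, which remains an observation without an assigned cause.

From the compounds shown here alone, it remains open whether the step tracks the loss of the donor or the larger group, since methylamino, dimethylamino or a ring amine such as piperidine at the same place would be needed to separate these two differences. Going by these compounds, it is equally open whether diethylamino gives a step of similar size on the core of compound 3, which carries nitro and lacks the N-methyl group of compound 1.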